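This account rests on a few compounds, and the source may have more. Where it says the series, first, only, none or still open, it means among the compounds named here.

Compound 1 `COc1cc(-c2nc(-c3ccccc3)[nH]c2-c2ccnc(NCCCNS(=O)(=O)c3ccc(F)cc3)n2)ccc1Cl`: 4530 nM
Compound 2 `COc1cc(-c2nc(-c3ccccc3)[nH]c2-c2ccnc(NCCCNS(=O)(=O)c3ccc(C(F)(F)F)cc3)n2)ccc1Cl`: 1780 nM
Compound 3 `O=S(=O)(NCCCNc1nccc(-c2[nH]c(-c3ccccc3)nc2-c2ccc(F)c(O)c2)n1)c1ccc(F)cc1`: 19200 nM

These three compounds were tested in a functional assay on LOX IMVI cells (Homo sapiens) for cytotoxicity, read by MTT assay, with a stated time of 24 h; on this read-out lower numbers stand for stronger inhibition and higher numbers for weaker inhibition. Compound 4 `O=S(=O)(NCCCNc1nccc(-c2[nH]c(-c3ccccc3)nc2-c2ccc(F)c(O)c2)n1)c1ccc(C(F)(F)F)cc1` has not yet been measured there. Compound 2 differs from compound 1 by trifluoromethyl in place of fluoro on an aromatic carbon, and that change gave a 2.5-fold lower number from compound 1 to compound 2 (0.41 log units; beyond the scatter). Compound 3 carries a different core than compound 1, the difference being (4-fluoro-3-hydroxyphenyl in place of 4-chloro-3-methoxyphenyl on an aromatic carbon), and this gave a 4.2-fold higher number from compound 1 to compound 3 (0.63 log units; beyond the scatter). Compound 4 differs from compound 3 by trifluoromethyl in place of fluoro on an aromatic carbon, which is the same change as from compound 1 to compound 2, at a place described in the same words. Within the data shown here, the step from compound 3 to compound 4 is expected to be a 2.5-fold lower number from compound 3 to compound 4 (0.40 log units; beyond the scatter), because the one earlier example of this change gave a 2.5-fold lower number from compound 1 to compound 2 (0.41 log units; beyond the scatter). This rests on a single pair, so the range is kept wide. Compound 4 is therefore expected to give about 7700 nM, with a likely range from 3000 nM to 20000 nM.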

Compound 4, half-maximal inhibitory concentration: 2450 nM
Compound 4: middle estimate off by 3.1-fold (0.50 log units), on the high side; the measured number lies below the stated range.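

In this assay, trifluoromethyl in place of fluoro gives a lower number on both cores, and on the second core the change gives a 7.8-fold lower number from compound 3 to compound 4 (0.89 log units; beyond the scatter), so the direction carries over but the size does not: the same change on two cores in this assay, a 2.5-fold lower number (0.41 log units; beyond the scatter) from compound 1 to compound 2 and a 7.8-fold lower number (0.89 log units; beyond the scatter) from compound 3 to compound 4, 3.1-fold (0.49 log units) apart, beyond the scatter of two such steps. The swap of 4-chloro-3-methoxyphenyl for 4-fluoro-3-hydroxyphenyl also depends on its partner, since with trifluoromethyl present it gives only a 1.4-fold higher number from compound 2 to compound 4 (0.14 log units; within the scatter): the same change on two cores in this assay, a 4.2-fold higher number (0.63 log units; beyond the scatter) from compound 1 to compound 3 and a 1.4-fold higher number (0.14 log units; within the scatter) from compound 2 to compound 4, 3.1-fold (0.49 log units) apart, beyond the scatter of two such steps. These two pairs do not show why the sizes differ, or what size to expect on a further core.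

The compounds shown leave open how a nitrile or an amine would behave in place of the trifluoromethyl. They also leave open whether a longer chain would change these steps.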